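Trifluoromethyl in Place of Chloro: What to Expect

A few compounds are considered here, and "the series" means these few. Any claim that something is new, unique, unknown or untested is made for them only; others in the source may bear on it.

Going by the values given here, compound 2 `CSc1ccc(Cl)cc1NCC1=NCCN1` is one of two compounds measured in an assay for binding affinity to Alpha-1A adrenergic receptor (Homo sapiens), read by radioligand binding; on this read-out higher numbers stand for weaker inhibition and lower numbers for stronger inhibition. In this measurement compound 2 gives 18.6 nM, the lowest of the two numbers; its nearest neighbour is compound 1 `CSc1ccc(C)cc1NCC1=NCCN1`, which gives 20.9 nM. Among the compounds with values here, the only step between the measured compounds, a 1.1-fold lower number from compound 1 to compound 2 (0.05 log units; within the scatter), exchanges chloro for methyl on an aromatic carbon and stays within the scatter, so the two values cannot be told apart.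

Compound 3 `CSc1ccc(C(F)(F)F)cc1NCC1=NCCN1` has not yet been measured. It differs from compound 2 by trifluoromethyl in place of chloro on an aromatic carbon. Within the data shown here, only one measured step bears on this change, and only loosely: it shows that exchanging methyl and chloro at this aromatic carbon gave a step within the scatter. Among the measured compounds shown here, no measured step shows what trifluoromethyl does at this place. On this basis the step from compound 2 to compound 3 is expected to be small, a 1.1-fold higher number from compound 2 to compound 3 (0.03 log units; within the scatter), with no direction beyond the scatter. Compound 3 is therefore estimated at 20 nM in this assay, in a range from 8 nM to 50 nM.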

Compound 3, inhibition constant: 589 nM
For compound 3 the middle estimate is 29-fold (1.47 log units) below the measured one, and the stated range ends below it.
By their numbers in this assay, from the lowest: compounds 2 and 1 (each within the scatter of the next); then compound 3.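

In this assay, the aromatic carbon para to the methylsulfanyl group turns out not to accept every small substituent equally: trifluoromethyl gives (a 32-fold higher number from compound 2 to compound 3 (1.50 log units; beyond the scatter)) and, measured against methyl, (a 28-fold higher number from compound 1 to compound 3 (1.45 log units; beyond the scatter)). Going by these compounds alone, the earlier pair could not reveal this, as their single step stayed within the scatter, so the likeness of methyl and chloro at this carbon does not carry over to trifluoromethyl, which brings 4 heavy atoms where chloro brings 1. Both large steps point the same way, so compound 3 stands clearly apart from the other two compounds, while compound 1 and compound 2 remain indistinguishable from each other, and no measurement offered here explains why this single exchange weighs so heavily.

Within the data shown here, with only three groups at this carbon, it remains open where between chloro and trifluoromethyl the sharp change sets in, and a bromine atom, an ethyl group or a methoxy group there would help to locate it. On these data alone, it is also open whether trifluoromethyl would give a step of this size at another carbon of the ring, or with an ethylsulfanyl group in place of the methylsulfanyl group.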